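Moving the hydroxyl from compound 3 to its isomer compound 4

The source may report more compounds than this note shows. Statements on the series, on what has been measured and on what is new or still open speak of the compounds shown alone.

Compound 3 `Oc1cccc(-c2cc(-c3cccc(Cl)c3)nc(-c3cccs3)c2)c1` stands lowest of the three numbers in a functional assay on DU-145 cells (Homo sapiens) for cytotoxicity, read by CCK-8 assay and cell counting, with a stated time of 2 days (a lower number here means a stronger inhibitor, a higher number a weaker inhibitor), where compound 3 gives 2650 nM. Its nearest neighbour is compound 2 `Oc1ccc(-c2cc(-c3ccsc3)nc(-c3cccc(Cl)c3)c2)cc1`, which in this assay gives 6220 nM, and the furthest is compound 1 `Oc1cccc(-c2cc(-c3ccc(Cl)cc3)nc(-c3cccs3)c2)c1`, which in this assay gives 11600 nM. Within the data shown here, the only single-point step among them, a 4.4-fold lower number from compound 1 to compound 3 (0.64 log units; beyond the scatter), concerns the chlorophenyl group and not the hydroxyphenyl one.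

Compound 4 `Oc1ccc(-c2cc(-c3cccc(Cl)c3)nc(-c3cccs3)c2)cc1` differs from compound 3 by 4-hydroxyphenyl in place of 3-hydroxyphenyl on an aromatic carbon. Among the measured compounds shown here, no measured step bears directly on this change; compound 2 also carries a 4-hydroxyphenyl group, but it differs from compound 3 in two places, so its value shows only that such a compound can sit a little weaker than compound 3 in this assay. Compound 4 is therefore expected to stay close to compound 3, with a step of a 1.3-fold higher number from compound 3 to compound 4 (0.12 log units; within the scatter) that is not confidently beyond the scatter. The estimate for compound 4 in this assay is 3500 nM, with a range from 1200 nM to 10000 nM.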

Compound 4, half-maximal inhibitory concentration: 5740 nM
For compound 4 the middle estimate is 1.6-fold (0.21 log units) below the measured one; measured number inside the range.
By their numbers in this assay, from the lowest: compound 3; then compounds 4, 2 and 1 (each within the scatter of the next, the first and the last beyond it).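

At the carbon opposite the ring nitrogen, in this assay, the placing of the hydroxyl alone changes the result: the two isomers have the same atoms joined differently, yet the 4-hydroxyphenyl group gives a weaker inhibitor (a 2.2-fold higher number from compound 3 to compound 4 (0.34 log units; beyond the scatter)). With the 4-hydroxyphenyl group in place, exchanging the thiophene attachment leaves the result within the scatter (a 1.1-fold lower number from compound 2 to compound 4 (0.03 log units; within the scatter)), so the two thiophene isomers cannot be told apart in this pair. Nothing available explains why the hydroxyl's placing matters.

All the compounds shown carry a hydroxyl, so what an amine or a carboxylic acid in its place would give remains open. As far as these compounds go, it is also open whether the two thiophene isomers would stay as close with the 3-hydroxyphenyl group in place.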